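This account rests on a few compounds, and the source may have more. Where it says the series, first, only, none or still open, it means among the compounds named here.

Measured so far in a functional assay on Jurkat cells (Homo sapiens) for inhibition, read by CCK-8 assay, with a stated time of 48 h; a lower number here means a stronger inhibitor of growth, a higher number a weaker inhibitor of growth:
compound 1 `Cc1ccccc1Nc1nc(Nc2ccc(N3CCN(C)CC3)cn2)ncc1Cl`: 8080 nM
compound 2 `CN1CCN(c2ccc(Nc3ncc(Cl)c(Nc4ccccc4)n3)nc2)CC1`: > 100000 nM
compound 3 `CN1CCN(c2ccc(Nc3ncc(Cl)c(NCc4ccccc4)n3)nc2)CC1`: > 100000 nM

Compound 3 has no number of its own. Its > 100000 nM is a limit of this assay, not a measurement. Compound 2 likewise gives only a limit, > 100000 nM. This is the limit of > 100000 nM in this assay, at which 2 of the 3 values shown sit. Compound 1 alone gives a real number, 8080 nM.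

Compound 4 `CN1CCN(c2ccc(Nc3ncc(Cl)c(NCc4ccc(C(F)(F)F)cc4)n3)nc2)CC1` is compound 3 with trifluoromethyl in place of hydrogen on an aromatic carbon, para to a large group: trifluoromethyl in place of hydrogen on an aromatic carbon.

Among the compounds with values here, two measured steps bear on this change, and both are large. In an at least 12-fold higher number from compound 1 to compound 2 (1.09 log units; beyond the scatter), the change is hydrogen in place of methyl on an aromatic carbon, the closest match, though it runs the other way and involves a different group. In an at least 12-fold higher number from compound 1 to compound 3 (1.09 log units; beyond the scatter), benzyl replaces 2-methylphenyl. From the compounds shown here alone, both steps end at the limit, so their true sizes remain unknown. The step that the two limits leave unreadable from compound 2 to compound 3 cannot be read at all.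

Since compound 3 sits at the limit, the only readable move is towards a lower number, and a modest gain is expected, with a real chance that only a limit is reported again. The expected change is an at least 2.5-fold lower number from compound 3 to compound 4 (0.39 log units; beyond the scatter). For compound 4 the estimate is 40000 nM, within an expected range of 10000 nM to 100000 nM.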

Compound 4, concentration for 50% growth inhibition: 7960 nM
Beside the measured number, compound 4's estimate is 5.0-fold (0.70 log units) above it; measured number below the stated range.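

In this assay, replacing benzyl with 4-(trifluoromethyl)benzyl brings a real number out of a compound that had none, an at least 12-fold lower number from compound 3 to compound 4 (1.09 log units; beyond the scatter), and the comparison with the plain phenyl compound is printed at the same size, an at least 12-fold lower number from compound 2 to compound 4 (1.09 log units; beyond the scatter). From the compounds shown here alone, the true size of both steps stays unknown, because compound 2 and compound 3 each give only a limit: the limit of > 100000 nM in this assay, at which 2 of the 4 values shown sit A real number has now come from two different substituted groups on this nitrogen, 2-methylphenyl and 4-(trifluoromethyl)benzyl, and the gap between them cannot be told from ordinary scatter, a 1.0-fold lower number from compound 1 to compound 4 (0.01 log units; within the scatter), so in these four compounds only those with a substituted aromatic ring give a readable value.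

The compounds shown do not tell whether trifluoromethyl itself matters or whether another group in the same place, such as a methoxy group, a chlorine atom or a carboxylic acid, would serve equally well. They also leave open what a longer chain between the nitrogen and the aromatic ring would do to growth inhibition.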